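The source may hold more compounds than are shown below. What is called first, only, known or untested is meant among the compounds shown, and "the series" means these compounds.

Working notes on the series

Three compounds share the same core, and all three have numbers in a functional assay for inhibition of sodium/hydrogen exchanger (Oryctolagus cuniculus); a lower number here means a stronger inhibitor, a higher number a weaker inhibitor. Compound 1 `CCc1cc(C)c(C(=O)N=C(N)N)cc1S(C)(=O)=O` gives 4.8 nM in this assay, compound 2 `CCCc1cc(C)c(C(=O)N=C(N)N)cc1S(C)(=O)=O` gives 5.7 nM, and compound 3 `Cc1cc(O)c(S(C)(=O)=O)cc1C(=O)N=C(N)N` gives 220 nM. Compound 3 stands highest of the three: the nearest is compound 2, reached by a 39-fold higher number from compound 2 to compound 3 (1.59 log units; beyond the scatter), and the furthest is compound 1, reached by a 46-fold higher number from compound 1 to compound 3 (1.66 log units; beyond the scatter). Lengthening the chain from compound 1 to compound 2 gave a 1.2-fold higher number from compound 1 to compound 2 (0.07 log units; within the scatter), so the two chain compounds cannot be told apart.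

Compound 4 `Cc1cc(OC2CCCCC2)c(S(C)(=O)=O)cc1C(=O)N=C(N)N` is not yet measured. It differs from compound 3 in one place: cyclohexyl in place of hydrogen on an oxygen on an aromatic ring. The hydroxy of compound 3 thus becomes cyclohexyloxy, so the hydrogen on that oxygen is gone and a six-membered ring of carbon is added on an oxygen on an aromatic ring whose other neighbours are aromatic carbon.

For the measured compounds named here, the steps that bear on this are those from the ethyl and propyl compounds to the hydroxy compound, both large. Going from compound 3 to compound 4 removes the hydroxy hydrogen and puts carbon back at that position, so a step towards lower numbers in this assay is expected, though no measured step covers an ether at this place. For compound 4 the expected step is an 8.8-fold lower number from compound 3 to compound 4 (0.94 log units; beyond the scatter). The estimate for compound 4 is 25 nM, with a range from 5 nM to 120 nM.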

Compound 4, half-maximal inhibitory concentration: 37 nM
The estimate for compound 4 lay 1.5-fold (0.17 log units) below the measured number; the range from low to high includes it.
By their numbers in this assay, from the lowest: compounds 1 and 2 (each within the scatter of the next); then compound 4; then compound 3.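

In this assay, replacing the hydrogen on the oxygen of compound 3 with cyclohexyl recovers part of what the hydroxy compound lost (a 5.9-fold lower number from compound 3 to compound 4 (0.77 log units; beyond the scatter)), so this position accepts a six-membered carbon ring carried on an oxygen and is not limited to small chains on the aromatic carbon. The recovery is only partial. The cyclohexyloxy compound still falls short of both chain compounds (a 6.5-fold higher number from compound 2 to compound 4 (0.81 log units; beyond the scatter); a 7.7-fold higher number from compound 1 to compound 4 (0.89 log units; beyond the scatter)), and at this place the ether does not match propyl or ethyl in this assay. Nothing available accounts for any of these steps.

Compound 4 changes two things at once, losing the hydrogen on the oxygen and gaining the ring, and the compounds shown cannot separate these two contributions. On these data alone, it also remains open whether a small ether such as methoxy, an open-chain ether such as butoxy, or an amine in place of the oxygen would come closer to the ethyl and propyl compounds than cyclohexyloxy does.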